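Removing the Phenyl Group from Compound 1

A few compounds are considered here, and "the series" means these few. Any claim that something is new, unique, unknown or untested is made for them only; others in the source may bear on it.

Compound 1 `CC(C)n1nc(-c2cc(-c3ccccc3)on2)c2c(N)ncnc21`: 4970 nM
Compound 2 `CC(C)(O)Cn1nc(-c2cc(C3CC3)on2)c2c(N)ncnc21`: 6750 nM

Of the compounds shown here, two have been measured in an assay on BaF3 cells for inhibition of proto-oncogene tyrosine-protein kinase receptor Ret variant V804M (Homo sapiens), read by MTT assay, with a stated time of 48 h; a higher number here means a weaker inhibitor of growth, a lower number a stronger inhibitor of growth. Compound 1 gives 4970 nM, and compound 2 gives 6750 nM. Compound 1 has the lowest of the two numbers, but its gap to compound 2 lies within the scatter, so the two cannot be placed in order. Compound 3 `CC(C)n1nc(-c2ccon2)c2c(N)ncnc21` differs from compound 1 at a single place: hydrogen in place of phenyl on an aromatic carbon. A phenyl leaves and only a hydrogen enters on that aromatic carbon. Among the measured compounds shown here, no pair of measured compounds shows what the loss of this group does, so the size of the step is not known from the data. The expectation is nevertheless a step from compound 1 to compound 3 of a 3.0-fold higher number from compound 1 to compound 3 (0.48 log units; beyond the scatter) in this assay, toward a higher number and beyond the scatter. Compound 3 is accordingly expected at 15000 nM, with a likely range from 5000 nM to 45000 nM.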

Compound 3, concentration for 50% growth inhibition: 8940 nM
Estimate against measurement, compound 3: 1.7-fold (0.22 log units) above; the range from low to high includes it.
By their numbers in this assay, from the lowest: compounds 1, 2 and 3 (each within the scatter of the next).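

With hydrogen in place of phenyl on this aromatic carbon, next to the ring oxygen, the result is a 1.8-fold higher number from compound 1 to compound 3 (0.25 log units; within the scatter) in this assay, a step that cannot be told apart from repeat-measurement noise. So a whole six-membered aromatic ring of six carbon atoms can leave this position without a clear step in the number, and the phenyl is not shown to be required for the growth inhibition seen with compound 1. No measurement shown here accounts for this result.

On these data alone, whether an amine, a carboxylic acid or a longer chain on this carbon would move the number clearly away from those of compound 1 and compound 3 remains open. Compound 2 differs from compound 3 in more than one place, so it cannot show what its cyclopropyl group alone does here.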